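Notes on replacing 2-cyanophenyl with 3-hydroxyphenyl

The source may report more compounds than this note shows. Statements on the series, on what has been measured and on what is new or still open speak of the compounds shown alone.

Measured so far:
compound 1, `O=C(CN1CCC(c2cccc[n+]2[O-])CC1)Nc1cccc(Cl)c1`, 62 nM
compound 2, `Cc1cccc(NC(=O)CN2CCC(c3ccccc3C#N)CC2)c1`, 8 nM

Both numbers come from a functional assay on HEK293 cells for agonist activity at D(4) dopamine receptor (Homo sapiens), read by FLIPR; on this read-out higher numbers stand for an effect only at larger amounts of compound and lower numbers for an effect already at smaller amounts. Compound 2 gives the lower of the two numbers and compound 1 the higher; the gap between them lies beyond the scatter. Going by the values given here, no pair of measured compounds differs in only one place, so no single-point step is available to lean on.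

Compound 3, `Cc1cccc(NC(=O)CN2CCC(c3cccc(O)c3)CC2)c1`, has not been measured in this assay. It differs from compound 2 as follows: 3-hydroxyphenyl in place of 2-cyanophenyl on a saturated ring carbon. The 2-cyanophenyl of compound 2 leaves and 3-hydroxyphenyl enters on a saturated ring carbon, three ring bonds from the ring nitrogen.

Among the compounds with values here, with no measured step of this kind, the expectation rests on compound 2 alone, which in this assay gives 8 nM. The expected step is a moderate rise in the number, a 3.8-fold higher number from compound 2 to compound 3 (0.57 log units; beyond the scatter), somewhat beyond the scatter but not large, with a wide range on either side. Compound 3 is estimated at 30 nM in this assay, with a range from 8 nM to 120 nM.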

Compound 3, half-maximal effective concentration: 8 nM
Compound 3: the middle estimate sits 3.8-fold (0.57 log units) above what was measured, and the stated range covers the measured number.
By their numbers in this assay, from the lowest: compounds 2 and 3 (each within the scatter of the next); then compound 1.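

In this assay, going by these compounds alone, 3-hydroxyphenyl in place of 2-cyanophenyl on the saturated ring carbon, three ring bonds from the ring nitrogen, gives no change at the digits printed from compound 2 to compound 3 (within the scatter), the only single-place step so far. This position therefore accepts two different substituted phenyl groups without a separation in the read-out: one with a nitrile and no hydrogen-bond donor, the other with a hydroxyl and one hydrogen-bond donor. Nothing measured here speaks to why the two groups read alike.

As far as these compounds go, the step changes the substituent and its place on the aromatic ring together, so it remains open whether the same result would hold for 3-cyanophenyl or 2-hydroxyphenyl, which would separate those two changes. Also open, from the compounds shown here alone, are the unsubstituted phenyl group and other replacements such as 3-methoxyphenyl or 3-aminophenyl, while compound 1 differs from compound 2 and compound 3 in more than one place and so cannot show how its own groups contribute.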